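The source may report more compounds than this note shows. Statements on the series, on what has been measured and on what is new or still open speak of the compounds shown alone.

Compound 3 `CCc1nc(-c2ccc(Cl)cc2Cl)c(CC)nc1NC(C1CC1)C1CC1` gives the lowest number of the three in an assay on IMR-32 cells for displacement of a labelled ligand from corticotropin-releasing factor receptor 1 (Homo sapiens), read by scintillation counting, with a stated time of 2 h (a higher number here means a weaker inhibitor, a lower number a stronger inhibitor), at 3.7 nM. Compound 1 `CCC(CC)Nc1nc(OC)c(-c2ccc(Cl)cc2Cl)nc1C` comes nearest with 14.4 nM, while compound 2 `CCc1nc(-c2ccc(OC)cc2O)c(CC)nc1NC(CC)CC` sits far away at 1180 nM. Compound 4 `CCCN(CCN(C)C)c1nc(CC)c(-c2ccc(Cl)cc2Cl)nc1CC` keeps the core of compound 3 and changes one group: (2-(dimethylamino)ethyl)(propyl)amino in place of (dicyclopropylmethyl)amino on an aromatic carbon. Within the data shown here, no pair among the measured compounds differs in only this place, so the size of the step is unknown. The shared replacement of a donor-bearing amine by a tertiary chain leads to the expectation of a moderate loss, beyond the scatter, from compound 3 to compound 4 an 8.1-fold higher number from compound 3 to compound 4 (0.91 log units; beyond the scatter). Compound 4 is therefore expected to give about 30 nM in this assay, within a range from 8 nM to 150 nM.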

Compound 4, inhibition constant: 1540 nM
Estimate against measurement, compound 4: 51-fold (1.71 log units) below; the measured number lies above the stated range.
By their numbers in this assay, from the lowest: compound 3; then compound 1; then compounds 2 and 4 (each within the scatter of the next).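

In this assay, among these compounds, (2-(dimethylamino)ethyl)(propyl)amino in place of (dicyclopropylmethyl)amino gives a 420-fold higher number from compound 3 to compound 4 (2.62 log units; beyond the scatter) and is the first step read at this aromatic carbon, showing that the number here depends strongly on the amine it carries. The change removes the hydrogen-bond donor and both three-membered rings and adds a second nitrogen, so this single step cannot assign the rise to any one of these. Nothing available explains the size of the step. Open, from the compounds shown here alone, is how a dipropylamino group, without the dimethylamino end, would compare, and likewise a (2-(dimethylamino)ethyl)amino group, which keeps the amine hydrogen.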